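This account rests on a few compounds, and the source may have more. Where it says the series, first, only, none or still open, it means among the compounds named here.

Three measured compounds set the scene. Compound 1 `Cc1cc(OCCCS(C)(=O)=O)cc(C)c1-c1cccc(COc2ccc(CCC(=O)O)cc2)c1` gives 15.5 nM in a functional assay on CHO cells for agonist activity at Free fatty acid receptor 1 (Homo sapiens), read by FLIPR and calcium flux; on this read-out higher numbers stand for an effect only at larger amounts of compound and lower numbers for an effect already at smaller amounts. Compound 2 `CCCOc1cc(C)c(-c2cccc(COc3ccc(S(=O)(=O)CC(=O)O)cc3)c2)c(C)c1` gives 69.2 nM in this assay, and compound 3 `Cc1ccccc1-c1cccc(COc2ccc(S(=O)(=O)CC(=O)O)cc2)c1` gives 46.8 nM. Compound 3 therefore holds the second highest of the three numbers; its value and that of compound 2 sit within the usual scatter of each other, so nothing separates the two, whereas compound 1 gives a lower number by a margin that goes beyond the scatter.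

Compound 4 `Cc1ccc(-c2cccc(COc3ccc(S(=O)(=O)CC(=O)O)cc3)c2)c(Cl)c1` has not yet been measured. Set against compound 3 the change is 2-chloro-4-methylphenyl in place of 2-methylphenyl on an aromatic carbon. Going by the values given here, no two measured compounds differ in a single place, so no measured step shows what such a change does to the read-out, and the expectation rests only on the structural change and on the value of compound 3. The expected step is a 1.2-fold lower number from compound 3 to compound 4 (0.07 log units; within the scatter), a shift that may well stay within the scatter and whose direction is uncertain, since the group leaving and the group entering are counted as closely alike. Compound 4 is thus expected to give about 40 nM, with a range running from 15 nM to 110 nM.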

Compound 4, half-maximal effective concentration: 36.3 nM
Estimate against measurement, compound 4: 1.1-fold (0.04 log units) above; measured number inside the range.
By their numbers in this assay, from the lowest: compound 1; then compounds 4, 3 and 2 (each within the scatter of the next).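

Going by these compounds alone, putting 2-chloro-4-methylphenyl in place of 2-methylphenyl gives a 1.3-fold lower number from compound 3 to compound 4 (0.11 log units; within the scatter) in this assay and is the first single-place step available in this set, so compound 3 and compound 4 cannot be told apart on this read-out. The result shows that this aromatic ring, meta to a large group, can carry a group of 8 heavy atoms, including chlorine, in place of one of 7 without a change beyond the scatter. Nothing at hand explains why the number stays within the scatter under this change.

The chlorine and the 4-methyl enter together, so this single step cannot show what either does alone, and a small net effect could hide two larger opposing ones or two with no effect at all. It also leaves open whether a larger or different group at this place, such as a methoxy group, an amine or a longer alkyl chain, would stay as close to compound 3, and how the same change would read out on the core of compound 1 or compound 2.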